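This account rests on a few compounds, and the source may have more. Where it says the series, first, only, none or still open, it means among the compounds named here.

In an ADME assay on HeLa cells (Homo sapiens) for cytotoxicity, read by crystal violet staining, with a stated time of 72 h (on this read-out lower numbers stand for higher toxicity in this test and higher numbers for lower toxicity in this test), compound 1 `CCOC(=O)c1cc(CCCOc2ccc(-c3noc(C(F)(F)F)n3)cc2OC)on1` gives > 100000 nM, which is a limit of the assay and not a number. Compound 2 `COc1cc(-c2noc(C(F)(F)F)n2)ccc1OCCCc1cc(C(=O)N(C)C)no1` reads 68000 nM, the higher of the two actual numbers, and compound 3 `COc1cc(-c2noc(C(F)(F)F)n2)cc([N+](=O)[O-])c1OCCCc1cc(C(=O)N(C)C)no1` reads 25600 nM. Compound 4 `CN(C)C(=O)c1cc(CCCOc2ccc(-c3noc(C(F)(F)F)n3)cc2N)on1` has amino in place of methoxy on an aromatic carbon. Of the measured steps, an at least 1.4-fold lower number from compound 1 to compound 2 (0.16 log units; that floor lies within the scatter) concerns a carbonyl carbon and says little here. The closer guide is a 2.7-fold lower number from compound 2 to compound 3 (0.42 log units; beyond the scatter), a modest change on an aromatic carbon. A small change is therefore expected in this assay, with a 1.4-fold lower number from compound 2 to compound 4 (0.13 log units; within the scatter) estimated and no step beyond the scatter. The estimate for compound 4 is 50000 nM, within an expected range of 20000 nM to 100000 nM.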

Compound 4, half-maximal cytotoxic concentration: 90800 nM
Compound 4: middle estimate off by 1.8-fold (0.26 log units), on the low side, within the range that was stated.
By their numbers in this assay, from the lowest: compound 3; then compounds 2 and 4 (each within the scatter of the next). At a limit, above all of these: compound 1.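

In this assay, amino in place of methoxy on this aromatic carbon, ortho to a large group, gives a 1.3-fold higher number from compound 2 to compound 4 (0.13 log units; within the scatter), so the swap produces no readable change. This position therefore tolerates the replacement of methoxy by amino in this test, whereas the earlier step on the ring, a 2.7-fold lower number from compound 2 to compound 3 (0.42 log units; beyond the scatter), did move the number. Compound 1 stands at a limit, which is not a number: the limit of > 100000 nM in this assay, at which 1 of the 4 values shown sits.

Going by these compounds, whether a hydroxyl group or a dimethylamino group on this carbon would read the same remains open. So does whether amino behaves alike alongside the nitro group of compound 3.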